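The source may report more compounds than this note shows. Statements on the series, on what has been measured and on what is new or still open speak of the compounds shown alone.

In a functional assay on HCT-116 cells (Homo sapiens) for antiproliferative activity, read by MTT assay, with a stated time of 24 h (a higher number here means a weaker inhibitor, a lower number a stronger inhibitor), compound 1 (`COc1ccc(C(=O)/C=C/c2ccc(F)cc2)c2c1C=CC(C)(C)O2`) gives > 10000 nM as its reading, which is a limit and not a number. Compound 2 (`COc1ccc(C(=O)/C=C/c2cccc(F)c2)c2c1C=CC(C)(C)O2`) gives > 10000 nM as its reading, so it too stands only at a limit. Among the compounds with values here, the one measured step is a step that the two limits leave unreadable from compound 1 to compound 2 and it has no readable size. The measurements so far amount to the limit of > 10000 nM in this assay, at which 2 of the 2 values shown sit, and nothing finer. Compound 3 (`COc1ccc(C(=O)/C=C/c2cccc([N+](=O)[O-])c2)c2c1C=CC(C)(C)O2`) now carries nitro in place of fluoro on an aromatic carbon, meta to a large group: nitro in place of fluoro on an aromatic carbon is the whole difference. Within the data shown here, with no sized step to carry over, the data give no firm direction for this change. The expected outcome is a step that the limit leaves unreadable from compound 2 to compound 3 in this estimate, and another limit reading is the likeliest result. For compound 3 the estimated value is 12000 nM with an expected range from 4000 nM to 40000 nM as its upper end.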

Compound 3, half-maximal inhibitory concentration: 8050 nM
Beside the measured number, compound 3's estimate is 1.5-fold (0.17 log units) above it, and the stated range covers the measured number.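

In this assay, within the data shown here, compound 3 is the first one here whose reading is a number and not a limit, so this position now has a reading that later changes can be compared with. Nitro in place of fluoro gives an at least 1.2-fold lower number from compound 2 to compound 3 (0.09 log units; that floor lies within the scatter), and 3-nitrophenyl in place of 4-fluorophenyl gives an at least 1.2-fold lower number from compound 1 to compound 3 (0.09 log units; that floor lies within the scatter); since each of these is only a floor, the true size of each step stays unknown, while the step between the two fluoro compounds cannot be read at all. Limits still make up most of the series: the limit of > 10000 nM in this assay, at which 2 of the 3 values shown sit.

Going by these compounds, what remains open is how far the number would move with an amine or a carboxylic acid on the same aromatic carbon. On these data alone, it is also open whether any such group would give a step from compound 3 that lies beyond the scatter.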